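A few compounds are considered here, and "the series" means these few. Any claim that something is new, unique, unknown or untested is made for them only; others in the source may bear on it.

The measured compounds:

Compound 1 `CCCCNC(=O)N1Cc2c(NC(=O)c3ccc(OC)cc3)nn(C(=O)C3CC3)c2C1`, tested in a functional assay on HCT-116 cells (Homo sapiens) for cytotoxicity, read by sulforhodamine B assay, with a stated time of 48 h (on this read-out higher numbers stand for weaker inhibition and lower numbers for stronger inhibition), gives 65500 nM.
Compound 2 `CCCCNC(=O)N1Cc2c(NC(=O)c3ccc(OC)cc3)nn(C(=O)c3ccccc3)c2C1` gives 25300 nM.
Compound 3 `COc1ccc(C(=O)Nc2nn(C(=O)C3CC3)c3c2CN(C(=O)c2ccccc2)C3)cc1` gives 5180 nM.

Compound 4 `COc1ccc(C(=O)Nc2nn(C(=O)c3ccccc3)c3c2CN(C(=O)c2ccccc2)C3)cc1` has not yet been measured. All four compounds share most of their framework, and the differences among them lie in two places. Compound 3 differs from compound 1 in its core by one exchange, (phenyl in place of butylamino on a carbonyl carbon), and this exchange is tied to the biggest change seen so far: a 13-fold lower number from compound 1 to compound 3 (1.10 log units; beyond the scatter). Compound 3 therefore stands with the lowest number of the three measured compounds, and its steps to the other two are beyond the usual scatter.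

The change that turns compound 3 into compound 4 is phenyl in place of cyclopropyl on a carbonyl carbon. The very same change, at a place described in the same words, has already been made once: compound 2 differs from compound 1 by phenyl in place of cyclopropyl on a carbonyl carbon, and that gave a 2.6-fold lower number from compound 1 to compound 2 (0.41 log units; beyond the scatter), a modest step. Since the place is identical word for word, this is the same change, made on a different core.

Among the measured compounds shown here, with only one earlier instance to lean on, the expectation is that the step from compound 3 to compound 4 will be about as large as the earlier one, that is a 2.6-fold lower number from compound 3 to compound 4 (0.41 log units; beyond the scatter), because the earlier instance gave a 2.6-fold lower number from compound 1 to compound 2 (0.41 log units; beyond the scatter). On that basis, compound 4 is estimated to give about 2000 nM in this assay, most likely somewhere between 800 nM and 5000 nM.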

Compound 4, half-maximal inhibitory concentration: 31300 nM
For compound 4 the middle estimate is 16-fold (1.19 log units) below the measured one, and the stated range ends below it.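

In this assay, the phenyl-for-cyclopropyl exchange on a carbonyl carbon now gives a 6.0-fold higher number from compound 3 to compound 4 (0.78 log units; beyond the scatter), so it did not carry over from one core to the other and its direction reversed: the same change on two cores in this assay, a 2.6-fold lower number (0.41 log units; beyond the scatter) from compound 1 to compound 2 and a 6.0-fold higher number (0.78 log units; beyond the scatter) from compound 3 to compound 4, 16-fold (1.19 log units) apart, beyond the scatter of two such steps

The other exchange, phenyl in place of butylamino on a carbonyl carbon, did not carry over either: it gives a 1.2-fold higher number from compound 2 to compound 4 (0.09 log units; within the scatter), leaving the two numbers indistinguishable, whereas it made a large difference on the core with cyclopropyl: the same change on two cores in this assay, a 13-fold lower number (1.10 log units; beyond the scatter) from compound 1 to compound 3 and a 1.2-fold higher number (0.09 log units; within the scatter) from compound 2 to compound 4, 16-fold (1.19 log units) apart, beyond the scatter of two such steps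

These four compounds show that, here, the result of an exchange at one place depends on the group at the other, so a step measured on one core is a poor guide to the same step on another, but they do not show why this happens, and with one pair per core they cannot say which step is more typical of the series.

From the compounds shown here alone, it remains open whether this dependence would also appear with other groups, such as a longer alkylamino chain in place of butylamino or a methyl or cyclobutyl group in place of cyclopropyl. Going by these compounds, it is also open whether any such group would give a lower number than compound 3, which has the lowest number of the four.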